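The source may hold more compounds than are shown below. What is called first, only, known or untested is meant among the compounds shown, and "the series" means these compounds.

Measured so far:
Compound 1, `COC(c1cc(Cl)c2c(c1Cl)C(=O)N(Cc1c(C)cc(C)[nH]c1=O)CC2)C1CCN(C2COC2)CC1`, gives 7 10^-6 cm/s; 7.9 10^-6 cm/s (2 entries) in an ADME assay on MDCK cells (Canis lupus familiaris) for permeability, read by LC-MS, with a stated time of 90 min, tested at 2 uM; on this read-out lower numbers stand for lower permeability and higher numbers for higher permeability.
Compound 2, `COc1cc(C)[nH]c(=O)c1CN1CCc2c(Cl)cc([C@@H](O)C3COC3)c(Cl)c2C1=O`, gives 1.2 10^-6 cm/s.
Compound 3, `Cc1cc(C)c(CN2CCc3c(Cl)cc([C@H](CO)[C@@H]4CCCO4)c(Cl)c3C2=O)c(=O)[nH]1`, gives 14.6 10^-6 cm/s.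

Compound 2 stands lowest of the two single numbers in this assay. Its nearest neighbour, compound 3, lies far above it, a gap well beyond the usual scatter. The two entries of compound 1 the several entries of compound 1 in this assay, 7 10^-6 cm/s; 7.9 10^-6 cm/s (2 entries) fall between them and agree closely with each other, which shows how tightly repeated readings of this kind can sit.

Compound 4, `COc1cc(C)[nH]c(=O)c1CN1CCc2c(Cl)cc(-c3c(C)noc3C)c(Cl)c2C1=O`, is not yet measured. It differs from compound 2 in one place:
a group of 7 heavy atoms (5 carbon, 1 nitrogen, 1 oxygen; one five-membered aromatic ring with 2 hetero atoms) in place of a group of 6 heavy atoms (4 carbon, 2 oxygen; one four-membered non-aromatic ring with 1 hetero atom), on an aromatic carbon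
Going by the values given here, no measured pair shows this same change, so its effect cannot be read off directly. Starting from the low number of compound 2, a rise in this assay is expected, of a size beyond the scatter, which would bring compound 4 close to the region where compound 1 and compound 3 sit. The step from compound 2 to compound 4 is estimated as an 8.3-fold higher number from compound 2 to compound 4 (0.92 log units; beyond the scatter). Compound 4 is therefore expected to give about 10 10^-6 cm/s, within a range from 4 10^-6 cm/s to 25 10^-6 cm/s.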

Compound 4, apparent permeability: 11 10^-6 cm/s
Estimate against measurement, compound 4: 1.1-fold (0.04 log units) below; the range from low to high includes it.
By their numbers in this assay, from the lowest: compound 2; then compounds 4 and 3 (each within the scatter of the next).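

The group on this aromatic carbon, ortho to a chloro group, now proves able to move the read-out on its own: putting 3,5-dimethyl-1,2-oxazol-4-yl in place of the group with the four-membered non-aromatic ring gives a 9.2-fold higher number from compound 2 to compound 4 (0.96 log units; beyond the scatter) in this assay. This one change swaps several things at once, a non-aromatic ring for an aromatic one and a group with 1 hydrogen-bond donor for one with 0 hydrogen-bond donors, so the step cannot be pinned on any single feature. The step is far wider than the spread between repeat readings, which sit close together: the several entries of compound 1 in this assay, 7 10^-6 cm/s; 7.9 10^-6 cm/s (2 entries)

As far as these compounds go, whether the rise comes from the aromatic ring or from the loss of the hydrogen-bond donor stays open. A phenyl ring or a primary amine on this carbon could help separate the two, and this single pair cannot show whether the step holds on other versions of the core.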